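Replacing the Ethylsulfamoyl of Compound 3 with a Urea

The source may report more compounds than this note shows. Statements on the series, on what has been measured and on what is new or still open speak of the compounds shown alone.

Of the compounds shown here, three have been measured in an assay on COS-7 cells for inhibition of patatin-like phospholipase domain-containing protein 2 (Mus musculus); a higher number here means a weaker inhibitor, a lower number a stronger inhibitor. Compound 1 `CCOC(=O)c1cccc(-c2ccc(O)cc2)c1` gives 100000 nM, compound 2 `CCOC(=O)c1cccc(-c2ccc(CN(C)C)cc2)c1` gives 150000 nM, and compound 3 `CCNS(=O)(=O)c1cccc(-c2ccc(OCC)cc2)c1` gives 200000 nM, a number within the usual scatter of both compound 1 and compound 2. Within the data shown here, the only measured step, a 1.5-fold higher number from compound 1 to compound 2 (0.18 log units; within the scatter), concerns a different change and does not bear directly on the new one. Compound 4 `CCOc1ccc(-c2cccc(NC(=O)N(C)C)c2)cc1` differs from compound 3 by (dimethylcarbamoyl)amino in place of ethylsulfamoyl on an aromatic carbon. Among the measured compounds shown here, with no step informing this change, no movement beyond the scatter is expected, and the estimated step of a 1.3-fold lower number from compound 3 to compound 4 (0.12 log units; within the scatter) is small. Compound 4 is therefore expected to give about 150000 nM in this assay, within a range of 40000 nM to 500000 nM.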

Compound 4, half-maximal inhibitory concentration: 70000 nM
The estimate for compound 4 lay 2.1-fold (0.33 log units) above the measured number; measured number inside the range.
By their numbers in this assay, from the lowest: compounds 4, 1, 2 and 3 (each within the scatter of the next, the first and the last beyond it).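

In this assay, the exchange gives a 2.9-fold lower number from compound 3 to compound 4 (0.46 log units; beyond the scatter), the first step shown that lies beyond the scatter, so the number does respond, modestly, to what sits on this aromatic carbon. Among these compounds, the only earlier step concerned a different change and stayed within the scatter. No measured evidence here explains this shift.

As far as these compounds go, it remains open whether an amine, a carboxylic acid or a longer chain at this place would move the number further. Also open, from the compounds shown here alone, is whether (dimethylcarbamoyl)amino would give a similar step on the core of compound 1 or compound 2.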